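Swapping a Bromine for a Methyl on the Sulfonyl Ring

The compounds below may be only part of what the source reports. "The series", "measured", "known", "first", "only" and "open" are said of these compounds alone.

Of the compounds shown here, three sharing one core have been tested in a functional assay on DU-145 cells (Homo sapiens) for inhibition, read by trypan blue exclusion, with a stated time of 96 h; on this read-out lower numbers stand for stronger inhibition of growth and higher numbers for weaker inhibition of growth. Compound 1 `COc1ccc(/C=C(\C(=O)c2ccc(Br)cc2)S(=O)(=O)c2ccc(Br)cc2)cc1` gives 25000 nM, and compound 3 `O=C(/C(=C\c1ccc(OC(F)(F)F)cc1)S(=O)(=O)c1ccc(Br)cc1)c1ccc(Br)cc1` gives 25000 nM; these two stand together at the highest numbers of the three, with no change at the digits printed from compound 1 to compound 3 (within the scatter). Compound 2 `O=C(/C(=C\c1ccc(Cl)c([N+](=O)[O-])c1)S(=O)(=O)c1ccc(Br)cc1)c1ccc(Br)cc1` gives 10000 nM, and the step of a 2.5-fold lower number from compound 1 to compound 2 (0.40 log units; beyond the scatter) is modest.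

Compound 4 `COc1ccc(/C=C(\C(=O)c2ccc(Br)cc2)S(=O)(=O)c2ccc(C)cc2)cc1` is not yet measured. It differs from compound 1 in one place: methyl in place of bromo on an aromatic carbon. Cut one bond further out, this reads 4-bromophenyl to 4-methylphenyl, on the ring carrying the sulfonyl group.

Neither measured step bears on this part of the molecule. The step from compound 1 to compound 2 and the step from compound 1 to compound 3 both alter the aryl group on the double-bonded chain carbon, not the sulfonyl ring. With no guidance for the sulfonyl ring, the expected step is no change at the digits printed from compound 1 to compound 4 (within the scatter), none beyond the scatter. Compound 4 is therefore estimated at 25000 nM, expected to fall between 10000 nM and 60000 nM.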

Compound 4, concentration for 50% growth inhibition: 1000 nM
For compound 4 the middle estimate is 25-fold (1.40 log units) above the measured one; measured number outside the range, below it.
By their numbers in this assay, from the lowest: compound 4; then compound 2; then compounds 1 and 3 (each within the scatter of the next).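

The ring carrying the sulfonyl group turns out to be a sensitive part of the molecule in this assay: 4-methylphenyl in place of 4-bromophenyl gives a 25-fold lower number from compound 1 to compound 4 (1.40 log units; beyond the scatter). The earlier changes, all on the aryl group of the double-bonded chain carbon, produced a modest step at most, whereas this exchange of one heavy atom for another, with no donor, acceptor or charge added or lost, produces a large one. Nothing available explains why this exchange matters so much.

The compounds shown leave open whether methyl is special here, since an ethyl group, a methoxy group or an amine at this place on the ring would be needed to tell. They also leave open whether the same exchange would act alike with the 4-chloro-3-nitrophenyl group of compound 2.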